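The source may report more compounds than this note shows. Statements on the series, on what has been measured and on what is new or still open speak of the compounds shown alone.

Measured compounds:
compound 1 `N#Cc1cccc(-c2cnc(C(=O)CCCCCCc3ccccc3)o2)c1` with 15 nM
compound 2 `COc1ccnc(-c2cnc(C(=O)CCCCCCc3ccccc3)o2)c1` with 0.8 nM
compound 3 `CN(C)C(=O)c1cnc(C(=O)CCCCCCc2ccccc2)o1` with 2 nM

All three were tested in an assay (Rattus norvegicus) for inhibition of Fatty-acid amide hydrolase 1 (Homo sapiens); a higher number here means a weaker inhibitor, a lower number a stronger inhibitor. Compound 3 stands second highest of the three numbers. Its nearest neighbour is compound 2, reached by a 2.5-fold higher number from compound 2 to compound 3 (0.40 log units; beyond the scatter), and its furthest is compound 1, reached by a 7.5-fold lower number from compound 1 to compound 3 (0.88 log units; beyond the scatter). Compound 2 sets the lowest number, with a 19-fold lower number from compound 1 to compound 2 (1.27 log units; beyond the scatter) the largest step in the set.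

Compound 4 `CSc1cnc(C(=O)CCCCCCc2ccccc2)o1` differs from compound 3 in one place: methylsulfanyl in place of dimethylcarbamoyl on an aromatic carbon.

Both measured steps into compound 3 replace an aromatic group by dimethylcarbamoyl, and they were modest in size. Among the compounds with values here, no measured step replaces dimethylcarbamoyl by a small group such as methylsulfanyl, so the change into compound 4 has no direct precedent here. What the three compounds do show is that a small group on this carbon can hold a low number, as compound 3 itself does with 2 nM. A step upward of modest size is therefore expected, worded as a 10-fold higher number from compound 3 to compound 4 (1.00 log units; beyond the scatter), though within wide uncertainty. Compound 4 is expected to give 20 nM in this assay, with a range of 5 nM to 80 nM.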

Compound 4, inhibition constant: 25 nM
Compound 4: the middle estimate sits 1.3-fold (0.10 log units) below what was measured, within the range that was stated.
By their numbers in this assay, from the lowest: compound 2; then compound 3; then compounds 1 and 4 (each within the scatter of the next).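

Exchanging dimethylcarbamoyl for methylsulfanyl on this aromatic carbon gives a large step in this assay (a 13-fold higher number from compound 3 to compound 4 (1.10 log units; beyond the scatter)), so the low number of compound 3 cannot be read as holding for any group without a ring at this position. The gap to the 4-methoxypyridin-2-yl group is wider still (a 31-fold higher number from compound 2 to compound 4 (1.49 log units; beyond the scatter)), while methylsulfanyl and 3-cyanophenyl cannot be told apart (a 1.7-fold higher number from compound 1 to compound 4 (0.22 log units; within the scatter), within the scatter), so the presence of an aromatic group does not by itself order these compounds: compound 1 and compound 2 both carry one yet differ widely, and compound 1 matches compound 4, which carries none. Nothing given here explains these differences.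

Going by these compounds, it remains open whether the low number of compound 3 needs the whole dimethylcarbamoyl group, which a carboxylic acid, a methyl ester or an unsubstituted carboxamide on this carbon would begin to test. Also open, on these data alone, is how methylsulfonyl, a simple amine or a chlorine atom would read at this position, and whether a longer chain on the sulfur would shift the number of compound 4.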